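Aromatic oxygen side chains: compound 3 to compound 4

The compounds below may be only part of what the source reports. "The series", "measured", "known", "first", "only" and "open" are said of these compounds alone.

- compound 1 `c1cc([C@H]2CC[C@]3(CC2)OOC2(O3)C3CC4CC(C3)CC2C4)ccc1OCCOC1CCNCC1` gives 50 ug/mL
- compound 2 `c1cc([C@H]2CC[C@]3(CC2)OOC2(O3)C3CC4CC(C3)CC2C4)ccc1OCC1CCNCC1` gives 12.5 ug/mL
- compound 3 `CC(C)(CN)Oc1ccc([C@H]2CC[C@]3(CC2)OOC2(O3)C3CC4CC(C3)CC2C4)cc1` gives > 100 ug/mL
- compound 4 `CC1(C)CC(O)(COc2ccc([C@H]3CC[C@]4(CC3)OOC3(O4)C4CC5CC(C4)CC3C5)cc2)CC(C)(C)N1` is not yet measured

In a physicochemical assay for solubility, read by nephelometry, measured as kinetic solubility, with a stated time of 30 min (on this read-out lower numbers stand for lower solubility and higher numbers for higher solubility), compound 3 reads > 100 ug/mL and this is a limit, not a number. Two measured steps place it in the series: an at least 8.0-fold higher number from compound 2 to compound 3 (0.90 log units; beyond the scatter) and an at least 2.0-fold higher number from compound 1 to compound 3 (0.30 log units; that floor lies within the scatter) are the comparisons available.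

The next change is (4-hydroxy-2,2,6,6-tetramethylpiperidin-4-yl)methyl in place of 1-(aminomethyl)-1-methylethyl on an oxygen on an aromatic ring and it sits on an oxygen on an aromatic ring. Compound 2 is the closest measured neighbour, as the entering group also holds a (piperidin-4-yl)methyl unit on that oxygen. Read backwards, an at least 8.0-fold higher number from compound 2 to compound 3 (0.90 log units; beyond the scatter) points to a lower number for compound 4. The step of a 4.0-fold lower number from compound 1 to compound 2 (0.60 log units; beyond the scatter) shows that two ring-bearing chains can themselves sit apart, so compound 4 need not fall as far as compound 2.

A modest step downward is therefore expected in this assay and its size stays uncertain, as the starting point is only a limit. The estimated step is an at least 2.8-fold lower number from compound 3 to compound 4 (0.45 log units; beyond the scatter) on this reading. Compound 4 is estimated at 35 ug/mL with an expected range from 12 ug/mL to 100 ug/mL for that measurement.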

Compound 4, solubility: > 100 ug/mL
Compound 4 was reported as a limit (the forecaster's own chance of this, stated with the estimate: 20%); middle value at least 2.8-fold (0.45 log units) from the limit.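

In this assay compound 4 gives > 100 ug/mL, which is a limit of the assay and not a number. Among the compounds shown here, on an oxygen on an aromatic ring, a chain that holds a six-membered non-aromatic ring with a piperidine nitrogen therefore need not read as low as compound 2, which the earlier compounds did not show: the hydroxy and tetramethyl substitution of the piperidin-4-yl unit gives an at least 8.0-fold higher number from compound 2 to compound 4 (0.90 log units; beyond the scatter), while the comparison with the longer ring-bearing chain gives an at least 2.0-fold higher number from compound 1 to compound 4 (0.30 log units; that floor lies within the scatter). The change from the 1-(aminomethyl)-1-methylethyl group to the (4-hydroxy-2,2,6,6-tetramethylpiperidin-4-yl)methyl group cannot be read, because compound 3 and compound 4 are both reported as limits: the limit of > 100 ug/mL in this assay, at which 2 of the 4 values shown sit.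

Going by these compounds, the hydroxyl and the four methyl groups enter together in compound 4, so their separate shares in the step from compound 2 stay open; a 4-hydroxypiperidin-4-yl or a 2,2,6,6-tetramethylpiperidin-4-yl group on the same saturated chain carbon would separate them. The compounds shown also leave open how a carboxylic acid at the end of a chain on this oxygen would read in this assay.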